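Replacing the Nitro Group of Compound 1 with Hydrogen

The source may hold more compounds than are shown below. What is called first, only, known or untested is meant among the compounds shown, and "the series" means these compounds.

Compound 1 (`O=[N+]([O-])c1ccc(/N=N/N2CCCC2)cc1`) has been measured in an ADME assay on Vero cells (Chlorocebus sabaeus) for cytotoxicity, read by crystal violet staining (on this read-out higher numbers stand for lower toxicity in this test and lower numbers for higher toxicity in this test), where compound 1 gives 90000 nM. For the measured compounds named here, it has only one measured neighbour. Compound 2 (`CCOC(=O)N1CCN(/N=N/c2ccccc2)CC1`) gives 90000 nM in this assay, so the two stand level, within the usual scatter.

The next compound to be tested is compound 3 (`c1ccc(/N=N/N2CCCC2)cc1`), which has hydrogen in place of nitro on an aromatic carbon of the core of compound 1. The change is hydrogen in place of nitro on an aromatic carbon.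

Going by the values given here, no measured pair of compounds shows this change on its own, so the expectation has little to rest on. Among the compounds with values here, the one indication is that compound 2, which carries no nitro group, gives 90000 nM. Losing the nitro group is therefore not expected to move the result in this assay in either direction beyond the usual scatter. The estimated no change at the digits printed from compound 1 to compound 3 (within the scatter) is accordingly expected to be no real change.

For compound 3 the expected value is 90000 nM, with an estimated range from 40000 nM to 200000 nM.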

Compound 3, half-maximal cytotoxic concentration: > 100000 nM
Compound 3: a limit, no number; the forecaster's own chance of this, stated with the estimate: 20%; at least 1.1-fold (0.04 log units) between middle value and limit.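

In this assay compound 3 gives > 100000 nM, which is a limit of the assay and not a number. For the compounds shown here, this pair is the first to show hydrogen in place of nitro on an aromatic carbon, para to a group of 7 heavy atoms, on its own, and the change gives an at least 1.1-fold higher number from compound 1 to compound 3 (0.04 log units; that floor lies within the scatter). Removing the nitro group therefore shows a direction on this read-out, but the floor of the step does not establish a change beyond the scatter, and its real size cannot be read because the result for compound 3 is a limit: the limit of > 100000 nM in this assay, at which 1 of the 3 values shown sits.

The compounds shown leave open how other groups on this aromatic carbon would read in this assay, for instance a nitrile, an amine or a carboxylic acid in place of the nitro group. Going by these compounds alone, they also leave open whether hydrogen in place of nitro would read the same way on another core, as this single pair is the only example of the change.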